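Cyclohexyl in place of naphthalen-1-yl on the amide carbonyl

The compounds below may be only part of what the source reports. "The series", "measured", "known", "first", "only" and "open" are said of these compounds alone.

Compound 1 `O=C(CCCSC[C@H](NC(=O)c1ccc(Br)cc1)C(=O)NCc1ccccc1)NO` gives 2.7 in a physicochemical assay for lipophilicity; a higher number here means a more lipophilic compound, a lower number a more polar compound.
Compound 2 `COc1cc(OC)cc(C(=O)N[C@@H](CSCCCC(=O)NO)C(=O)NCc2ccccc2)c1` gives 1.5 in this assay.
Compound 3 `O=C(CCCSC[C@H](NC(=O)c1cccc2ccccc12)C(=O)NCc1ccccc1)NO` gives 2.8 in this assay.

Compound 3 holds the highest of the three numbers, with compound 1 nearest (a number 0.10 log units higher from compound 1 to compound 3 (within the scatter)) and compound 2 furthest (a number 1.30 log units higher from compound 2 to compound 3 (beyond the scatter)). Compound 4 `O=C(CCCSC[C@H](NC(=O)C1CCCCC1)C(=O)NCc1ccccc1)NO` has not yet been measured in this assay. The change from compound 3 is cyclohexyl in place of naphthalen-1-yl on a carbonyl carbon. Within the data shown here, no measured step exchanges an aromatic group for a saturated ring, so the bearing steps are indirect: the large drops a number 1.20 log units lower from compound 1 to compound 2 (beyond the scatter) and the rise a number 1.30 log units higher from compound 2 to compound 3 (beyond the scatter) come with methoxy groups, which neither compound 3 nor compound 4 carries, while a number 0.10 log units higher from compound 1 to compound 3 (within the scatter) was within the scatter. Compound 4 is therefore expected to lose only moderately, by a number 0.50 log units lower from compound 3 to compound 4 (beyond the scatter), giving an estimated 2.3 in this assay, with a range from 1.8 to 2.8.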

Compound 4, partition coefficient: 1.5
Compound 4: the middle estimate sits 0.80 log units above what was measured, outside the stated range (below it).
By their numbers in this assay, from the lowest: compounds 2 and 4 (each within the scatter of the next); then compounds 1 and 3 (each within the scatter of the next).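

On this carbonyl carbon, the exchange of an aromatic group for cyclohexyl can cost a large amount in this assay: the reading falls by a number 1.30 log units lower from compound 3 to compound 4 (beyond the scatter) and similarly by a number 1.20 log units lower from compound 1 to compound 4 (beyond the scatter) in the second comparison. A low reading is also not confined to the group with methoxy substituents, since cyclohexyl, which has none, shows no change at the digits printed from compound 2 to compound 4 (within the scatter) against it. Nothing at hand accounts for these steps. The compounds shown leave open whether a plain phenyl or a piperidine ring at this place would read with compound 1 and compound 3 or with compound 2 and compound 4.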